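A few compounds are considered here, and "the series" means these few. Any claim that something is new, unique, unknown or untested is made for them only; others in the source may bear on it.

Compound 1 `C/N=C(/NC#N)NCCCCCCn1nc(-c2ccccc2)ccc1=O` was tested in a functional assay on the whole organism (stomach) with Rattus norvegicus as the target; on this read-out lower numbers stand for an effect already at smaller amounts and higher numbers for an effect only at larger amounts of compound. In this assay compound 1 gives only a limit, > 100 mg/kg, and not a number. Compound 2 `C/N=C(/NC#N)NCCCCn1nc(-c2ccccc2)c(C)cc1=O` likewise reaches only a limit, > 100 mg/kg. Compound 3 `NC(=O)SCCCCCN1NC=CC=C1c1ccccc1` gives 23.8 mg/kg. Among the values shown, compound 1 sits at the top edge, at the limit of > 100 mg/kg in this assay, at which 2 of the 3 values shown sit. Compound 4 `C/N=C(/NC#N)NCCCCCn1nc(-c2ccccc2)ccc1=O` has not yet been measured in this assay. It differs from compound 1 in one place: a group of 7 heavy atoms (3 carbon, 4 nitrogen; no ring) in place of a group of 8 heavy atoms (4 carbon, 4 nitrogen; no ring), on a saturated chain carbon, five bonds along the chain from an aromatic nitrogen. Among the compounds with values here, no pair of measured compounds differing in one place is known here, so the size of the step cannot be read from measured data. The step is expected to be a number no higher from compound 1 to compound 4 (the limit leaves the size open), none beyond the scatter, because the limit of > 100 mg/kg in this assay, at which 2 of the 3 values shown sit, holds for compound 1. Compound 4 is therefore estimated at 100 mg/kg, in a range from 30 mg/kg to 300 mg/kg, and most likely again reported only as a limit.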

Compound 4, dose for half-maximal effect: 100 mg/kg
Beside the measured number, compound 4's estimate shows no gap at the digits printed; measured number inside the range.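

In this assay compound 4, with the group of 7 heavy atoms, gives an actual number, 100 mg/kg, so a compound with this change can be placed on the scale. Compound 1, with the group of 8 heavy atoms, gives only a limit, > 100 mg/kg. The change gives a number no higher from compound 1 to compound 4 (the limit leaves the size open). The size of the step between these two compounds therefore cannot be read: the limit of > 100 mg/kg in this assay, at which 2 of the 4 values shown sit.

The compounds shown leave open whether a shorter chain, or a carboxylic acid at this place, would bring the effect down to smaller doses.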